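Series notes: pyrimidinyl for dimethoxyphenyl on compound 2

A few compounds are considered here, and "the series" means these few. Any claim that something is new, unique, unknown or untested is made for them only; others in the source may bear on it.

The series is followed in an ADME assay on HeLa cells (Homo sapiens) for cytotoxicity, read by ATP content, with a stated time of 3 days; on this read-out lower numbers stand for higher toxicity in this test and higher numbers for lower toxicity in this test. Compound 1 `O=c1n(Cc2cc3cnccc3n2CCCCO)c2cnccc2n1C1CC1` gives > 100000 nM, which is a limit of the assay and not a number. Compound 3 `O=c1n(Cc2nc3nc(Cl)ccc3n2CCCCO)c2cnccc2n1C1CC1` gives > 50000 nM, again a limit. Compound 2 `COc1ccc(-n2c(=O)n(Cc3cc4cc(Cl)ccc4n3CCCC#N)c3cnccc32)cc1OC` gives > 50000 nM, also a limit. Every value shown so far in this assay is therefore a limit, namely the limit of > 100000 nM in this assay, at which 1 of the 3 values shown sits, and (the limit of > 50000 nM in this assay, at which 2 of the 3 values shown sit), so compound 2 stands level with the other two and no ranking among the three can be drawn.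

Compound 4 `N#CCCCn1c(Cn2c(=O)n(-c3ncccn3)c3ccncc32)cc2cc(Cl)ccc21` differs from compound 2 in one place: pyrimidin-2-yl in place of 3,4-dimethoxyphenyl on an aromatic nitrogen. Going by the values given here, no measured pair in the set makes this or any other single change, so the size of such a step has no precedent here. With every compound shown sitting at a limit, the expected step that the limit leaves unreadable from compound 2 to compound 4 is none beyond the scatter. Compound 4 is accordingly estimated at 60000 nM, with a range from 20000 nM to 150000 nM, and the likeliest outcome is that this assay again reports only a limit.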

Compound 4, half-maximal cytotoxic concentration: > 50000 nM
Compound 4 gave a limit, no number; the forecaster's own chance of this, stated with the estimate: 80%; the middle value lies beyond the limit too.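

In this assay compound 4 gives > 50000 nM, a limit and not a number. Compound 2 gives > 50000 nM, also a limit, so no step can be read between compound 2 and compound 4. The compounds shown leave open whether pyrimidin-2-yl in place of 3,4-dimethoxyphenyl shifts this read-out at all.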